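Chloro step on the core of compound 1

The compounds below may be only part of what the source reports. "The series", "measured", "known", "first", "only" and "open" are said of these compounds alone.

- compound 1 `CCOC(=O)c1c(-c2cc(F)cc(OC)c2)[nH]c2cc(OC)ccc2c1=O`: > 21500 nM (limit)
- compound 2 `CCOC(=O)c1c(-c2cccc(C(C)=O)c2)[nH]c2cc(OC)ccc2c1=O`: > 21500 nM (limit)
- compound 3 `CCOC(=O)c1c(-c2cccc(O)c2)[nH]c2cc(OC)ccc2c1=O`: > 21500 nM (limit)

In an ADME assay on HepG2 cells (Homo sapiens) for cytotoxicity, read by luminescence, with a stated time of 72 h (on this read-out higher numbers stand for an effect only at larger amounts of compound and lower numbers for an effect already at smaller amounts), compound 1 gives > 21500 nM as a limit and not a number. It has company there: the limit of > 21500 nM in this assay, at which 3 of the 3 values shown sit, is all the series shows so far.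

Compound 4 `CCOC(=O)c1c(-c2cc(F)cc(OC)c2)[nH]c2cc(OC)c(Cl)cc2c1=O` differs from compound 1 in a single place: chloro in place of hydrogen on an aromatic carbon on the shared core, ortho to a methoxy group.

Three measured steps exist: a step that the two limits leave unreadable from compound 1 to compound 2 and a step that the two limits leave unreadable from compound 1 to compound 3 and a step that the two limits leave unreadable from compound 2 to compound 3. All of them exchange a group on the aromatic ring carried by the core, and none places a chloro on the core itself. They give no size and no direction for this change.

No step beyond the scatter can therefore be foreseen in this assay, and a further limit reading is the likeliest outcome. The expected step is a step that the limit leaves unreadable from compound 1 to compound 4 and remains a rough estimate. For compound 4 the estimated value is 25000 nM with an expected range from 12000 nM to 50000 nM as its ends.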

Compound 4, half-maximal effective concentration: > 21500 nM
Compound 4: only a limit was reported; the forecaster's own chance of this, stated with the estimate: 75%; the middle value lies beyond the limit too.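

In this assay compound 4 gives > 21500 nM, a limit and not a number. With compound 1 also at a limit, the chloro step between compound 1 and compound 4 cannot be read: the limit of > 21500 nM in this assay, at which 4 of the 4 values shown sit.

The compounds shown leave open whether any exchange in this series, chloro on the shared core included, shifts the read-out in this assay at all.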